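The compounds below may be only part of what the source reports. "The series", "measured", "known", "first", "only" and "open" are said of these compounds alone.

Measured so far:
- Compound 1 `CC(=O)Nc1nc(-c2cccc(NS(=O)(=O)c3ccc(C#C[Si](C)(C)C)cc3)c2)cs1`. In a functional assay on A-375 cells (Homo sapiens) for antiproliferative activity, read by trypan blue exclusion, with a stated time of 48 h, tested at 10 uM (on this read-out lower numbers stand for a stronger effect and higher numbers for a weaker effect at the one concentration tested), compound 1 gives < 1%, which is a limit of the assay rather than a number.
- Compound 2 `CCCCCCC#Cc1cccc(S(=O)(=O)Nc2cccc(-c3csc(NC(C)=O)n3)c2)c1`. In this assay compound 2 gives < 1%, again a limit of the assay.
- Compound 3 `CC(=O)Nc1nc(-c2cccc(NS(=O)(=O)c3cccc(C#C[Si](C)(C)C)c3)c2)cs1`. In this assay compound 3 gives 5.8%.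

Compound 1 therefore stands at a limit, not at a measured number: all that is known is the limit of < 1% in this assay, at which 2 of the 3 values shown sit. The piece follows the move from compound 1 to compound 4 `CCCCCCCCc1ccc(S(=O)(=O)Nc2cccc(-c3csc(NC(C)=O)n3)c2)cc1`, in which (a group of 8 heavy atoms (8 carbon; no ring) in place of a group of 6 heavy atoms (5 carbon, 1 silicon; no ring), on an aromatic carbon).

Among the compounds with values here, only one measured step is available for comparison. Going from compound 2 to compound 3, the group on a triple-bonded carbon was exchanged and the read-out moved by a number at least 4.8 percentage points higher from compound 2 to compound 3 (that floor lies within the scatter), a floor that lies within the scatter. That step keeps the triple bond and changes only what sits on it, whereas the move to compound 4 removes the whole triple-bonded group and puts an octyl chain directly on the aromatic carbon, so it is a weaker guide. On the three compounds in hand, nothing points to a shift beyond the scatter, so a small or absent step is expected. For compound 4 the value in this assay is estimated at 4%, within 0% to 15%, and the expected step is a number at least 3 percentage points higher from compound 1 to compound 4 (that floor lies within the scatter).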

Compound 4, a percentage reported as activity, at one concentration (the size of the read-out at that concentration, not a potency): < 1%
Compound 4 ended at the assay's limit; the forecaster's own chance of this, stated with the estimate: 45%; middle value at least 3 percentage points from the limit.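

Compound 1 and compound 4 both end at a limit of this assay rather than at a number, so no step between them can be read: the limit of < 1% in this assay, at which 3 of the 4 values shown sit.

The compounds shown leave open whether putting octyl in place of the silicon-bearing group changes the effect at all in this assay.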